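Cyanoguanidine series: benzyl replacement at the imine nitrogen substituent

The compounds below may be only part of what the source reports. "The series", "measured", "known", "first", "only" and "open" are said of these compounds alone.

Measured so far:
compound 1 `CCCCC/N=C(\NC#N)Nc1cccnc1` — 20 mg/kg
compound 2 `CCCC(C)(C)/N=C(\NC#N)Nc1cccnc1` — 1 mg/kg

Among the measured compounds shown here, in a functional assay on the whole organism (blood, strain Wistar-Okamoto) with Rattus norvegicus as the target, with a stated time of 5 days (a higher number here means that more compound is needed for the effect, a lower number that less compound is needed), compound 1 gives 20 mg/kg, the higher of the two numbers measured; its only neighbour is compound 2, and the step of a 20-fold lower number from compound 1 to compound 2 (1.30 log units; beyond the scatter) goes with 1,1-dimethylbutyl in place of pentyl on a double-bonded nitrogen.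

Compound 3 `N#CN/C(=N\Cc1ccccc1)Nc1cccnc1` has not been measured. It differs from compound 1 by phenyl in place of butyl on a saturated chain carbon bound to a double-bonded nitrogen. For the measured compounds named here, the one measured step concerns branching at the carbon bound to the double-bonded nitrogen, not the exchange of the butyl chain for phenyl, so it does not bear directly on this change; nothing else speaks to it. In this assay no step beyond the scatter is therefore expected, with a wide allowance in either direction.

For compound 3 the estimate in this assay is 15 mg/kg, with a range from 4 mg/kg to 60 mg/kg. This corresponds to an expected step of a 1.3-fold lower number from compound 1 to compound 3 (0.12 log units; within the scatter).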

Compound 3, minimum effective dose: 20 mg/kg
For compound 3 the middle estimate is 1.3-fold (0.12 log units) below the measured one, within the range that was stated.
By their numbers in this assay, from the lowest: compound 2; then compounds 1 and 3 (each within the scatter of the next).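

In this assay, phenyl in place of butyl on a saturated chain carbon bound to a double-bonded nitrogen gives no change at the digits printed from compound 1 to compound 3 (within the scatter) and so shows that a six-membered aromatic ring of carbon only can stand here in place of an open chain without a step beyond the scatter. Together with a 20-fold lower number from compound 1 to compound 2 (1.30 log units; beyond the scatter) for 1,1-dimethylbutyl in place of pentyl, this shows that not every replacement of the pentyl group moves the number: among the changes shown, only the one to compound 2 gives a step beyond the scatter. The data shown offer nothing that explains why the butyl-to-phenyl exchange leaves the number where it is.

Among the compounds shown here, still open is whether adding the two methyl groups of the 1,1-dimethylbutyl group to the carbon that carries the phenyl in compound 3 would go with a step like the one seen for compound 2. Equally open, as far as these compounds go, is how a phenyl carrying a chlorine, a chain ending in an amine or a carboxylic acid, or a longer chain such as heptyl would read at this place.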